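The source may report more compounds than this note shows. Statements on the series, on what has been measured and on what is new or still open speak of the compounds shown alone.

Measured in an assay on isolated protein for inhibition of proto-oncogene tyrosine-protein kinase receptor Ret variant V804M (Homo sapiens), read by radiometric assay and 33P incorporation, in the presence of a further agent that is not named here; on this read-out lower numbers stand for stronger inhibition and higher numbers for weaker inhibition:

Compound 1 `Nc1ncnc2c1c(-c1cc(C3CC3)on1)nn2C1CCCCC1`: 14 nM
Compound 2 `CCc1cc(-c2nn(C(C)C)c3ncnc(N)c23)no1`: 531 nM

Compound 1 stands at the lowest of the two numbers shown. Its nearest neighbour is compound 2, whose number lies higher by a margin beyond the usual scatter, so the two are distinguishable on this read-out.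

Compound 3 `CCCCCCCn1nc(-c2cc(C3CC3)on2)c2c(N)ncnc21` has not yet been measured. It differs from compound 1 in one place: heptyl in place of cyclohexyl on an aromatic nitrogen. No step between two measured compounds speaks to this kind of change, so there is no shown step to lean on. The account therefore treats the heptyl chain as a departure from a ring of similar size and expects compound 3 to give a somewhat higher number than compound 1, a modest step that may reach just beyond the scatter, a 2.9-fold higher number from compound 1 to compound 3 (0.46 log units; beyond the scatter). On that basis the estimate for compound 3 is 40 nM, with a range from 10 nM to 200 nM.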

Compound 3, half-maximal inhibitory concentration: 927 nM
The estimate for compound 3 lay 23-fold (1.37 log units) below the measured number, and the stated range ends below it.
By their numbers in this assay, from the lowest: compound 1; then compounds 2 and 3 (each within the scatter of the next).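

In this assay, the group on the aromatic nitrogen proves to matter a great deal: heptyl in place of cyclohexyl gives a 66-fold higher number from compound 1 to compound 3 (1.82 log units; beyond the scatter), a large step beyond the scatter, although both groups are made of carbon only and neither carries a hydrogen-bond donor, a hydrogen-bond acceptor or a net charge. At this position, then, an open chain of similar size does not stand in for the ring. Nothing available here explains the step.

The compounds shown leave open whether the change in number follows the loss of the ring or the length of the chain, a question that a shorter chain such as butyl or a smaller ring such as cyclopentyl on the same nitrogen would address. They also leave open how a ring bearing an amine would behave there.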